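Rearranging two hydroxy groups on the phenyl ring

The source may hold more compounds than are shown below. What is called first, only, known or untested is meant among the compounds shown, and "the series" means these compounds.

Measured in an ADME assay on K562 cells (Homo sapiens) for cytotoxicity, with a stated time of 72 h; a lower number here means a stronger inhibitor, a higher number a weaker inhibitor:
- compound 1 `Oc1ccccc1CNc1ncnc2c1ncn2C1CCCCO1` gives > 100000 nM 
- compound 2 `Oc1cccc(CNc2ncnc3c2ncn3C2CCCCO2)c1` gives 81000 nM 
- compound 3 `Oc1cccc(CNc2ncnc3c2ncn3C2CCCCO2)c1O` gives 92000 nM 

The entry for compound 1 is a limit of the assay and not a number. Compound 3 stands within the scatter of compound 2, so the data do not separate them.

Compound 4 `Oc1cc(O)cc(CNc2ncnc3c2ncn3C2CCCCO2)c1` differs from compound 3 only on the ring: 3,5-dihydroxyphenyl in place of 2,3-dihydroxyphenyl on a saturated chain carbon bound to a nitrogen on an aromatic ring with the same atoms joined differently. Going by the values given here, two measured steps bear on this. Replacing 2-hydroxyphenyl with 3-hydroxyphenyl gave an at least 1.2-fold lower number from compound 1 to compound 2 (0.09 log units; that floor lies within the scatter) and adding a hydroxy gave a 1.1-fold higher number from compound 2 to compound 3 (0.06 log units; within the scatter) and the first of these is only a floor. No step beyond the scatter is therefore expected, and the estimate amounts to a 1.1-fold lower number from compound 3 to compound 4 (0.03 log units; within the scatter) as the expected change. The estimated value for compound 4 is 85000 nM (expected range 50000 nM to 130000 nM).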

Compound 4, half-maximal inhibitory concentration: > 100000 nM
Compound 4: no number, only a limit (the forecaster's own chance of this, stated with the estimate: 30%); at least 1.1-fold (0.07 log units) between middle value and limit.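

In this assay compound 4 gives > 100000 nM, which is a limit of the assay and not a number. The change to 3,5-dihydroxyphenyl gave an at least 1.0-fold higher number from compound 3 to compound 4 (0.03 log units; that floor lies within the scatter), and adding a hydroxy gave an at least 1.2-fold higher number from compound 2 to compound 4 (0.09 log units; that floor lies within the scatter), so neither rearranging nor adding a hydroxy on this ring is yet shown to move the value beyond the scatter. The step between compound 1 and compound 4 cannot be read, because both sit at a limit: the limit of > 100000 nM in this assay, at which 2 of the 4 values shown sit.

Going by these compounds, how far compound 4 lies past its limit stays open, as does the effect of an amine or a carboxylic acid in place of a hydroxy on this ring.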